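The source may report more compounds than this note shows. Statements on the series, on what has been measured and on what is new or still open speak of the compounds shown alone.

Within the data shown here, compound 2, `Oc1cccc(-c2cc(-c3ccc(Cl)cc3)nc(-c3ccsc3)c2)c1`, is one of three compounds measured so far in an assay on isolated protein for inhibition of DNA topoisomerase 1 (Homo sapiens), with a stated time of 30 min, tested at 100 uM (on this read-out higher numbers stand for a stronger effect at the one concentration tested and lower numbers for a weaker effect), where compound 2 gives 11.7%. Compound 1, `Oc1cccc(-c2cc(-c3ccc(Cl)cc3)nc(-c3cccnc3)c2)c1`, gives 2.8%, and compound 3, `Oc1cccc(-c2cc(-c3ccsc3)nc(-c3cccc(Cl)c3)c2)c1`, gives 26.2%. Compound 2 thus stands second highest of the three numbers: its nearest neighbour is compound 1, with the step of a number 8.9 percentage points higher from compound 1 to compound 2 (within the scatter), while compound 3 lies furthest from it, the step of a number 14.5 percentage points higher from compound 2 to compound 3 (beyond the scatter).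

Compound 4, `Oc1cccc(-c2cc(-c3ccccc3)nc(-c3ccc(Cl)cc3)c2)c1`, differs from compound 2 in one place: phenyl in place of thiophen-3-yl on an aromatic carbon.

Among the measured compounds shown here, only one measured step bears on this change. Replacing one ring with another at the same position, thiophen-3-yl in place of pyridin-3-yl, gave the step of a number 8.9 percentage points higher from compound 1 to compound 2 (within the scatter), which is within the scatter. For the measured compounds named here, no measured step shows what a phenyl at this position does. On that basis a step of no size beyond the scatter is expected in this assay, and compound 4 is estimated to give 12%, between 2% and 24%, which means an expected step of a number 0.3 percentage points higher from compound 2 to compound 4 (within the scatter).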

Compound 4, a percentage reported as inhibition, at one concentration (the size of the read-out at that concentration, not a potency): 7.1%
Compound 4: middle estimate off by 4.9 percentage points, on the high side; measured number inside the range.
By their numbers in this assay, from the lowest: compounds 1, 4 and 2 (each within the scatter of the next); then compound 3.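

In this assay the change to phenyl gives a number 4.6 percentage points lower from compound 2 to compound 4 (within the scatter) and the change from pyridin-3-yl gives a number 4.3 percentage points higher from compound 1 to compound 4 (within the scatter) at the same place next to the ring nitrogen. With the earlier step between compound 1 and compound 2, all three exchanges among these rings now lie within the scatter, so at this position a six-membered aromatic ring of carbon only reads no differently from thiophen-3-yl or pyridin-3-yl. No measurement at hand offers an explanation for this result.

What the compounds shown leave open is whether anything at this position moves the number beyond the scatter, since all three groups here are aromatic rings. An amine, a carboxylic acid or a longer chain in place of the ring could answer that.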